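The source may hold more compounds than are shown below. What is called first, only, known or untested is meant among the compounds shown, and "the series" means these compounds.

In an assay on membranes from HeLa cells for displacement of a labelled ligand from adenosine receptor A3 (Homo sapiens), read by scintillation counting, with a stated time of 180 min, tested at 1 uM (on this read-out higher numbers stand for more inhibition at the one concentration tested (going by the name of the read-out) and lower numbers for less inhibition), compound 2 `CCSC(=O)C1=C(C)NC(=O)NC1c1ccsc1` gives 2%. Within the data shown here, the only other compound measured is compound 1 `CC(=O)C1=C(C)NC(=O)NC1c1ccsc1`, which gives 1% in this assay; the step of a number 1 percentage points higher from compound 1 to compound 2 (within the scatter) lies within the usual scatter, so the two numbers cannot be set one above the other, and both show next to no inhibition at the concentration tested. Compound 3 `CC1=C(c2ncc(C)o2)C(c2ccsc2)NC(=O)N1` carries the change (5-methyl-1,3-oxazol-2-yl in place of (ethylsulfanyl)carbonyl on a double-bonded ring carbon). Among the measured compounds shown here, no measured step touches this position or either of these groups; the single step in hand, a number 1 percentage points higher from compound 1 to compound 2 (within the scatter), concerns another group and was itself within the scatter, so it offers no direction for the new change. With both measured compounds near the floor of the read-out, the expected step of a number 1 percentage points higher from compound 2 to compound 3 (within the scatter) is none beyond the scatter. Compound 3 is therefore estimated at 3%, within a range of 0% to 12%.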

Compound 3, a percentage reported as inhibition, at one concentration (the size of the read-out at that concentration, not a potency): 2%
Compound 3: the middle estimate sits 1 percentage points above what was measured, and the stated range covers the measured number.
By their numbers in this assay, from the lowest: compounds 1, 2 and 3 (each within the scatter of the next).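

In this assay, putting 5-methyl-1,3-oxazol-2-yl in place of (ethylsulfanyl)carbonyl on the double-bonded ring carbon gives no change at the digits printed from compound 2 to compound 3 (within the scatter), and putting it in place of acetyl gives a number 1 percentage points higher from compound 1 to compound 3 (within the scatter). The earlier compounds shown here carried only carbonyl-linked groups at this position, and this result extends the picture to a five-membered aromatic ring: the reading still shows next to no inhibition at the concentration tested. All three groups therefore read alike here, and none stands out from the others. No available evidence bears on why the numbers stay this low.

With every number near the floor, the compounds shown cannot tell what this position accepts. On these data alone, it remains open whether a carboxylic acid or a longer alkyl ester here, or a phenyl group in place of thiophen-3-yl, would give a reading clear of the floor.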